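The source may report more compounds than this note shows. Statements on the series, on what has been measured and on what is new or still open speak of the compounds shown alone.

Measured compounds in a functional assay on HeLa cells (Homo sapiens) for cytotoxicity, read by CCK-8 assay, with a stated time of 72 h; a lower number here means a stronger inhibitor, a higher number a weaker inhibitor:
- compound 1 `C=CCn1c(=O)/c(=C\c2cccc(C)c2)[nH]c(=O)/c1=C\c1ccccc1OC`: 19300 nM
- compound 2 `C=CCn1c(=O)/c(=C\c2ccccc2F)[nH]c(=O)/c1=C\c1ccccc1OC`: 45000 nM
- compound 3 `C=CCn1c(=O)/c(=C\c2cc(OC)c(OC)c(OC)c2)[nH]c(=O)/c1=C\c1cccc(Br)c1`: "not active" (no number reported)

Compound 2 carries the highest of the two numbers; the nearest is compound 1, reached by a 2.3-fold higher number from compound 1 to compound 2 (0.37 log units; beyond the scatter). Compound 4 `C=CCn1c(=O)/c(=C\c2cccc(Cl)c2Cl)[nH]c(=O)/c1=C\c1ccccc1OC` has not been measured. Its change from compound 2: 2,3-dichlorophenyl in place of 2-fluorophenyl on a double-bonded chain carbon bound to an aromatic carbon. Among the measured compounds shown here, the only measured step touching this position is a 2.3-fold higher number from compound 1 to compound 2 (0.37 log units; beyond the scatter), a modest step beyond the scatter; no step involving a dichlorophenyl group exists. The whole set sits at weak values, and one compound gave no number at all. The expectation for compound 4 is therefore a step of about a 1.3-fold lower number from compound 2 to compound 4 (0.11 log units; within the scatter), with a real chance that only a limit is reported. Compound 4 is estimated at 35000 nM, within 12000 nM to 120000 nM.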

Compound 4, half-maximal inhibitory concentration: 1600 nM
Compound 4: the middle estimate sits 22-fold (1.34 log units) above what was measured, and the stated range ends above it.
By their numbers in this assay, from the lowest: compound 4; then compound 1; then compound 2.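

In this assay the place on a double-bonded chain carbon bound to an aromatic carbon turns out to carry large steps, not only the modest one seen earlier: 2,3-dichlorophenyl gives a 28-fold lower number from compound 2 to compound 4 (1.45 log units; beyond the scatter) and a 12-fold lower number from compound 1 to compound 4 (1.08 log units; beyond the scatter). Among the compounds shown here, compound 4 is therefore the first compound clearly separated from the weak values. No available data account for this gain.

Going by these compounds, whether one chlorine atom would suffice remains open. So does the outcome of placing an amine or a carboxylic acid on this phenyl ring.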